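Thiosemicarbazone series: ring swap on the thiocarbonyl carbon

This account rests on a few compounds, and the source may have more. Where it says the series, first, only, none or still open, it means among the compounds named here.

Of the compounds shown here, three have been measured in a functional assay on A-431 cells (Homo sapiens) for cytotoxicity, read by MTT assay, with a stated time of 72 h; a lower number here means a stronger inhibitor, a higher number a weaker inhibitor. Compound 1 `Cc1ccnc(/C(N)=N/NC(=S)N2CCSCC2)c1` gives 7200 nM, compound 2 `N/C(=N\NC(=S)N1CCSCC1)c1ccccn1` gives 6700 nM and compound 3 `Cc1ccnc(/C(N)=N/NC(=S)N2CCCCCC2)c1` gives 8000 nM. Compound 2 has the lowest of the three numbers, but its gaps to compound 1 and to compound 3 are both within the scatter, so no order among them can be read. For the measured compounds named here, the one single-point step measured, a 1.1-fold lower number from compound 1 to compound 2 (0.03 log units; within the scatter), is also within the scatter.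

Compound 4 `N/C(=N\NC(=S)N1CCCC1)c1ccccn1` differs from compound 2 in the ring attached to the thiocarbonyl carbon: pyrrolidin-1-yl in place of thiomorpholin-4-yl on a thiocarbonyl carbon. Going by the values given here, no measured step covers exactly this exchange. The closest comparison is compound 1 against compound 3, which differ only in that ring and whose two values lie within the scatter of each other. Nothing in the series therefore points to a sizeable step in this assay in either direction. Compound 4 is expected to sit close to compound 2, with an estimated step of a 1.0-fold higher number from compound 2 to compound 4 (0.02 log units; within the scatter). The estimate for compound 4 is 7000 nM, in a range from 3000 nM to 16000 nM.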

Compound 4, half-maximal inhibitory concentration: 1700 nM
Estimate against measurement, compound 4: 4.1-fold (0.61 log units) above; measured number outside the range, below it.
By their numbers in this assay, from the lowest: compound 4; then compounds 2, 1 and 3 (each within the scatter of the next).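

In this assay the ring on the thiocarbonyl carbon is a place where the number can move: pyrrolidin-1-yl in place of thiomorpholin-4-yl gives a 3.9-fold lower number from compound 2 to compound 4 (0.60 log units; beyond the scatter). Compounds 1 and 3, which differ only in that ring, had shown no such separation, with compound 1 at 7200 nM and compound 3 at 8000 nM, so not every ring exchange at this place acts alike. No measurement in hand bears on what lies behind the step.

The compounds shown do not separate ring size from the absence of the ring sulfur, a question that a piperidin-1-yl or a morpholin-4-yl group on the thiocarbonyl carbon would address. Also open, on these data alone, is whether pyrrolidin-1-yl gives a similar step on the methyl-bearing core of compound 1.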